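Swapping isopropyl for 2-carboxyethyl on the side chain

This account rests on a few compounds, and the source may have more. Where it says the series, first, only, none or still open, it means among the compounds named here.

In a functional assay on PC-3 cells (Homo sapiens) for antiproliferative activity, read by MTT assay, with a stated time of 24 h (on this read-out higher numbers stand for weaker inhibition and lower numbers for stronger inhibition), two compounds with the same core have been measured so far. Compound 1 `CCn1c(C(=O)NC2(C(=O)O)CC2)ccc1C(CC)(CC)c1ccc(OCS(=O)(=O)c2ccccc2)c(C)c1` gives 26300 nM, and compound 2 `CCn1c(C(=O)N[C@@H](C(=O)O)C(C)C)ccc1C(CC)(CC)c1ccc(OCS(=O)(=O)c2ccccc2)c(C)c1` gives 3070 nM, the lower of the two numbers and therefore the stronger inhibition.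

The next compound to be measured is compound 3 `CCn1c(C(=O)N[C@H](CCC(=O)O)C(=O)O)ccc1C(CC)(CC)c1ccc(OCS(=O)(=O)c2ccccc2)c(C)c1`. It differs from compound 2 in one place, with 2-carboxyethyl in place of isopropyl on a saturated chain carbon bound to an amide-type nitrogen and a carbonyl carbon.

Among the measured compounds shown here, only one measured step bears on this change: an 8.6-fold lower number from compound 1 to compound 2 (0.93 log units; beyond the scatter). That step, a modest one beyond the scatter, also altered the group on the amide-type nitrogen, so the number does respond to changes in this part of the molecule. Neither measured compound carries the 1,3-dicarboxypropyl group, so the direction remains uncertain. A step of comparable or smaller size towards weaker inhibition is expected, estimated as a 3.3-fold higher number from compound 2 to compound 3 (0.51 log units; beyond the scatter). For compound 3 the expected value is 10000 nM, with an estimated range of 2500 nM to 40000 nM.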

Compound 3, half-maximal inhibitory concentration: > 50000 nM
Compound 3: a limit, no number (the forecaster's own chance of this, stated with the estimate: 15%); at least 5.0-fold (0.69 log units) between middle value and limit.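

In this assay compound 3 gives no number, only a limit of the assay: the limit of > 50000 nM in this assay, at which 1 of the 3 values shown sits.

Even so, the saturated chain carbon bound to an amide-type nitrogen and a carbonyl carbon proves highly sensitive to its side chain, as 2-carboxyethyl in place of isopropyl brings an at least 16-fold higher number from compound 2 to compound 3 (1.21 log units; beyond the scatter), a large step and the first one shown at this carbon that runs towards weaker inhibition. The other new comparison, an at least 1.9-fold higher number from compound 1 to compound 3 (0.27 log units; that floor lies within the scatter), sets no firm order between those two compounds, while compound 2 remains the strongest inhibitor of the three.

The compounds shown leave open whether the added carboxylic acid or the different shape of the chain carries this change, as 2-carboxyethyl differs from isopropyl in both. A plain propyl chain, a shorter carboxymethyl chain, or a primary amide in place of that carboxylic acid at the end of the chain would help to separate the two.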